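Toward Compound 4: A New Group on the Urea Nitrogen

This account rests on a few compounds, and the source may have more. Where it says the series, first, only, none or still open, it means among the compounds named here.

The measured compounds:
Compound 1 `CCN1CCc2c(sc(NC(=O)Nc3ccc(Cl)cc3)c2C(N)=O)C1` gives 3120 nM.
Compound 2 `NC(=O)c1c(NC(=O)Nc2ccc(Cl)cc2)sc2c1CCN(CC1CCCC1)C2` gives 1830 nM.
Compound 3 `CC(C)(C)OC(=O)CCN1CCc2c(sc(NC(=O)Nc3ccc(Cl)cc3)c2C(N)=O)C1` gives 1100 nM.

In a functional assay (strain AB) with Danio rerio as the target, read by microscopy, with a stated time of 1 h (on this read-out higher numbers stand for an effect only at larger amounts of compound and lower numbers for an effect already at smaller amounts), compound 1 stands at the highest of the three numbers. The nearest of the other two is compound 2, with a 1.7-fold lower number from compound 1 to compound 2 (0.23 log units; within the scatter). The furthest is compound 3, with a 2.8-fold lower number from compound 1 to compound 3 (0.45 log units; beyond the scatter). Between the other pair there is a 1.7-fold lower number from compound 2 to compound 3 (0.22 log units; within the scatter). Going by the values given here, all three of these steps concern the group carried on the amine nitrogen in a ring of the shared core, and only the step to compound 3 goes beyond the scatter.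

Compound 4 `CCN1CCc2c(sc(NC(=O)NCc3cccc(Cl)c3)c2C(N)=O)C1` differs from compound 1 at a different place: 3-chlorobenzyl in place of 4-chlorophenyl on an amide-type nitrogen. None of the measured steps touches the urea side of the molecule, so no shown step bears directly on this change, and its direction cannot be read from the numbers at hand. In the absence of any bearing step, the expectation for compound 4 is a number close to that of compound 1, with a wide range on either side.

Compound 4 is therefore estimated at 3500 nM, within a range from 1000 nM to 12000 nM. This estimate corresponds to a 1.1-fold higher number from compound 1 to compound 4 (0.05 log units; within the scatter).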

Compound 4, half-maximal effective concentration: > 25000 nM
Compound 4: a limit, no number; the forecaster's own chance of this, stated with the estimate: 10%; middle value at least 7.1-fold (0.85 log units) away from the limit.
By their numbers in this assay, from the lowest: compounds 3, 2 and 1 (each within the scatter of the next, the first and the last beyond it). At a limit, above all of these: compound 4.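

Compound 4 gives > 25000 nM in this assay, and this value is a limit of the assay, not a number: the limit of > 25000 nM in this assay, at which 1 of the 4 values shown sits.

Putting 3-chlorobenzyl in place of 4-chlorophenyl on the amide-type nitrogen gives an at least 8.0-fold higher number from compound 1 to compound 4 (0.90 log units; beyond the scatter), a larger step than any of those seen among the groups on the amine nitrogen in a ring. Going by these compounds alone, both groups hold a six-membered aromatic ring of carbon only and a chlorine, so the step shows that keeping these parts is not enough to keep the effect at this place, which the earlier compounds, all alike on the urea side, could not reveal.

From the compounds shown here alone, whether the step follows the added chain carbon or the changed place of the chlorine stays open, and a 3-chlorophenyl or a 4-chlorobenzyl group on this nitrogen would separate the two. Also open, going by these compounds, is how far the urea side tolerates other groups, such as an unsubstituted phenyl, a pyridine ring or a longer chain ending in an aromatic ring, and whether any of them would give a lower number than compound 1 does.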